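A few compounds are considered here, and "the series" means these few. Any claim that something is new, unique, unknown or untested is made for them only; others in the source may bear on it.

Of the compounds shown here, three from one series have been tested in a functional assay on U-373MG ATCC cells (Homo sapiens) for inhibition, read by MTT assay, with a stated time of 72 h; on this read-out lower numbers stand for stronger inhibition and higher numbers for weaker inhibition. Compound 1 `CCC(=O)O[C@@H](/C(C)=C/[C@@H](C)c1oc(CC)c(C)c(=O)c1C)[C@H](C)[C@@H](OC(=O)CC(C)C)[C@@H](C)c1oc([C@@H](C)[C@@H](O)CC)c(C)c(=O)c1C` gives 21000 nM in this assay. Compound 2 `CCc1oc([C@H](C)/C=C(\C)[C@H](O)[C@H](C)[C@@H](OC(=O)CC(C)C)[C@@H](C)c2oc([C@@H](C)[C@@H](O)CC)c(C)c(=O)c2C)c(C)c(=O)c1C` differs from compound 1 by hydrogen in place of propanoyl on an oxygen on a saturated carbon, and that change gives an at least 4.7-fold higher number from compound 1 to compound 2 (0.67 log units; beyond the scatter). For compound 2 this assay reports only a limit, > 100000 nM, not a number (the limit of > 100000 nM in this assay, at which 1 of the 3 values shown sits). Compound 3 `CCC(=O)O[C@@H](/C(C)=C/[C@@H](C)c1oc(CC)c(C)c(=O)c1C)[C@H](C)[C@@H](OC(=O)CC(C)C)[C@@H](C)c1oc([C@@H](C)[C@H](CC)OC(C)=O)c(C)c(=O)c1C` differs from compound 1 by acetyl in place of hydrogen on an oxygen on a saturated carbon, and that step gives a 2.3-fold lower number from compound 1 to compound 3 (0.37 log units; beyond the scatter), so compound 3 gives 9000 nM in this assay.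

Compound 4 `CCc1oc([C@H](C)/C=C(\C)[C@H](OC(C)=O)[C@H](C)[C@@H](OC(=O)CC(C)C)[C@@H](C)c2oc([C@@H](C)[C@@H](O)CC)c(C)c(=O)c2C)c(C)c(=O)c1C` has not yet been measured. It differs from compound 2 by acetyl in place of hydrogen on an oxygen on a saturated carbon, the same change that was made from compound 1 to compound 3, where it gave a 2.3-fold lower number from compound 1 to compound 3 (0.37 log units; beyond the scatter). The place of the change is described in the same words in both cases. Compound 4 also stands close to compound 1, since only the acyl group on that oxygen differs. On that ground compound 4 is expected to give about 25000 nM, between 9000 nM and 70000 nM, in this assay, which would mean an at least 4.0-fold lower number from compound 2 to compound 4 (0.60 log units; beyond the scatter). The expectation rests on compound 1 giving 21000 nM in this assay. For compound 2 this assay gives only a limit.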

Compound 4, half-maximal inhibitory concentration: 21000 nM
Compound 4: middle estimate off by 1.2-fold (0.08 log units), on the high side, within the range that was stated.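

In this assay, acetyl in place of hydrogen on the core of compound 2 gives an at least 4.7-fold lower number from compound 2 to compound 4 (0.67 log units; beyond the scatter), so the number falls here as it did in the earlier step, and the direction of the change carries over to this second core. The size of the effect does not clearly carry over, and the two steps cannot be ranked: the same change on two cores in this assay, a 2.3-fold lower number (0.37 log units; beyond the scatter) from compound 1 to compound 3 and an at least 4.7-fold lower number (0.67 log units; beyond the scatter) from compound 2 to compound 4; the limit leaves it open whether they differ Compound 2 has only a limit, not a number, so its step shows a smallest possible size and no true size: the limit of > 100000 nM in this assay, at which 1 of the 4 values shown sits.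

With the oxygen acylated, acetyl and propanoyl read alike, with no change at the digits printed from compound 1 to compound 4 (within the scatter), but these two small acyl groups say nothing about whether a longer chain such as butanoyl, or a benzoyl group, on that oxygen would give the same number. Two cores are also too few to tell whether acetyl on a hydroxy oxygen would lower the number on other cores in this series.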